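The compounds below may be only part of what the source reports. "The series", "measured", "known", "first", "only" and "open" are said of these compounds alone.

Series notes. Compound 1 `CC(C)C[C@H](NC(=O)OCCc1cccc(Cl)c1)C(=O)N[C@H](C=O)C[C@@H]1CCNC1=O`, compound 2 `COc1cccc2[nH]c(C(=O)N[C@@H](CC(C)C)C(=O)N[C@H](C=O)C[C@@H]3CCNC3=O)cc12` and compound 3 `O=C[C@H](C[C@@H]1CCNC1=O)NC(=O)[C@H](CC1CC1)NC(=O)OCCc1cccc(Cl)c1` have been run in an ADME assay on Vero C1008 cells (Chlorocebus sabaeus) for cytotoxicity, read by luminescence and CellTiter-Glo, with a stated time of 24 h; a lower number here means that less compound is tolerated, a higher number that more compound is tolerated; compound 4 `COc1cccc2[nH]c(C(=O)N[C@@H](CC3CC3)C(=O)N[C@H](C=O)C[C@@H]3CCNC3=O)cc12` has not. In this assay compound 1 gives only a limit, > 200000 nM. Compound 2 likewise gives only a limit, > 200000 nM. Compound 3 also returns only a limit, > 200000 nM. The change from compound 1 to compound 3 is cyclopropyl in place of isopropyl on a saturated chain carbon, two bonds along the chain from an amide-type nitrogen and a carbonyl carbon, and the step it makes is a step that the two limits leave unreadable from compound 1 to compound 3; with the limit of > 200000 nM in this assay, at which 3 of the 3 values shown sit, on both sides, no size can be read from that pair. The difference between the cores of compound 1 and compound 2 is not broken down here. Compound 4 carries the same change on the core of compound 2: cyclopropyl in place of isopropyl on a saturated chain carbon, two bonds along the chain from an amide-type nitrogen and a carbonyl carbon. For compound 4 the expected step is a step that the limit leaves unreadable from compound 2 to compound 4, resting on the unreadable a step that the two limits leave unreadable from compound 1 to compound 3 and on (the limit of > 200000 nM in this assay, at which 3 of the 3 values shown sit), which gives no sign that this change moves the read-out. Compound 4 is therefore expected at 250000 nM, most likely reported again as a limit rather than a number, because the limit of > 200000 nM in this assay, at which 3 of the 3 values shown sit, is where every measured member of the series stands.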

Compound 4, half-maximal cytotoxic concentration: > 200000 nM
Compound 4: a limit, no number (the forecaster's own chance of this, stated with the estimate: 85%); the middle value is on the limit's open side.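

In this assay compound 4 gives only a limit, > 200000 nM. With compound 2 also at a limit, no step can be read between compound 2 and compound 4. The compounds shown leave open whether cyclopropyl in place of isopropyl moves the read-out at all, and where any of the four compounds would fall as an actual number.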